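From Cyclohexyl to Cycloheptyl on an Aromatic Nitrogen

A few compounds are considered here, and "the series" means these few. Any claim that something is new, unique, unknown or untested is made for them only; others in the source may bear on it.

In a toxicity assay on HT-29 cells (Homo sapiens) for cytotoxicity (on this read-out lower numbers stand for higher toxicity in this test and higher numbers for lower toxicity in this test), compound 3 (`CN1C(=S)[C@@H](NC(=O)c2nc(Cc3ccccc3)n(C3CCCCC3)n2)COc2ccccc21`) gives > 100000 nM as a limit of the assay, not a number. Compound 1 (`CCCCn1nc(C(=O)N[C@H]2COc3ccccc3N(C)C2=S)nc1Cc1ccccc1`) gives > 100000 nM as a limit too. Compound 2 (`CC(C)Cn1nc(C(=O)N[C@H]2COc3ccccc3N(C)C2=S)nc1Cc1ccccc1`) gives > 100000 nM as a limit too. The evidence so far is therefore the limit of > 100000 nM in this assay, at which 3 of the 3 values shown sit, and no measured number. Compound 4 (`CN1C(=S)[C@@H](NC(=O)c2nc(Cc3ccccc3)n(C3CCCCCC3)n2)COc2ccccc21`) carries cycloheptyl in place of cyclohexyl on an aromatic nitrogen. The steps bearing on this are a step that the two limits leave unreadable from compound 1 to compound 3 and a step that the two limits leave unreadable from compound 2 to compound 3 and a step that the two limits leave unreadable from compound 1 to compound 2 and none of them gives a size to carry over. No step beyond the usual scatter is expected, so the estimated change is a number no higher from compound 3 to compound 4 (the limit leaves the size open) with no clear direction. For compound 4 the estimate is 100000 nM with an expected range from 40000 nM to 200000 nM and another limit is likely.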

Compound 4, half-maximal cytotoxic concentration: > 100000 nM
Compound 4: no number, only a limit; the forecaster's own chance of this, stated with the estimate: 85%; the middle value sits exactly at the limit.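

Within the data shown here, compound 4 gives only a limit, as do compound 1, compound 2 and compound 3, so no step between them can be read. Whether any of these groups on the aromatic nitrogen changes the result in this assay remains open: the limit of > 100000 nM in this assay, at which 4 of the 4 values shown sit.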